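Extending the ether chain from compound 2 to compound 3

A few compounds are considered here, and "the series" means these few. Any claim that something is new, unique, unknown or untested is made for them only; others in the source may bear on it.

Going by the values given here, in a physicochemical assay for lipophilicity, read by HPLC, measured as octanol-water partition (a higher number here means a more lipophilic compound, a lower number a more polar compound), compound 1 `CCCCC(Sc1ncnc2c1cnn2-c1ccccc1Cl)C(=O)Nc1nc(C)cs1` gives 6.4 and compound 2 `COCCC(Sc1ncnc2c1cnn2-c1ccccc1Cl)C(=O)Nc1nc(C)cs1` gives 4.8 as the lower of the two numbers so far. Compound 3 `COCCOCCC(Sc1ncnc2c1cnn2-c1ccccc1Cl)C(=O)Nc1nc(C)cs1` differs from compound 2 by methoxymethyl in place of hydrogen on a saturated chain carbon bound to an oxygen on a saturated carbon with methoxymethyl in place of hydrogen on a saturated chain carbon bound to an oxygen on a saturated carbon. Among the compounds with values here, only one measured step bears on this change. That step, a number 1.60 log units lower from compound 1 to compound 2 (beyond the scatter) with methoxy in place of ethyl, exchanged carbon for oxygen, whereas the new change adds carbon along with oxygen, so only a small part of its size is expected to recur, in the same downward direction. The expected change is a number 0.20 log units lower from compound 2 to compound 3 (within the scatter) in this assay and may stay within the scatter. Compound 3 is estimated at 4.6 in this assay with an expected range of 4.1 to 5.1 for the measurement.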

Compound 3, distribution coefficient: 4.7
Compound 3: middle estimate off by 0.10 log units, on the low side; measured number inside the range.
By their numbers in this assay, from the lowest: compounds 3 and 2 (each within the scatter of the next); then compound 1.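

In this assay, the step of a number 0.10 log units lower from compound 2 to compound 3 (within the scatter) shows that methoxymethyl in place of hydrogen on a saturated chain carbon bound to an oxygen on a saturated carbon gives no readable shift at this position. Measured against the ethyl-bearing compound, 2-methoxyethoxy in place of ethyl gives a number 1.70 log units lower from compound 1 to compound 3 (beyond the scatter), so the large step seen with methoxy remains large with the extended group, and the added methoxymethyl contributes nothing beyond the scatter. Nothing at hand explains this flat reading.

The compounds shown leave open whether a longer chain of the same kind would also read alongside compound 2 in this assay. From the compounds shown here alone, how an amine or a carboxylic acid in place of the 2-methoxyethoxy group would read also remains open.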